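The compounds below may be only part of what the source reports. "The series", "measured", "known", "first", "only" and "open" are said of these compounds alone.

Measured compounds in a functional assay on the whole organism (strain albino) for inhibition, with Rattus norvegicus as the target, read by paw edema, with stated times of 30 min and 1 h, at a dose of 100 mg/kg by the oral route; on this read-out lower numbers stand for less inhibition and higher numbers for more inhibition at the one dose given (going by the name of the read-out):
Compound 1 `Nc1ccc(C(=O)/C=C/c2ccc(Cl)cc2)cc1` — 41%
Compound 2 `COc1ccc(/C=C/C(=O)c2ccc(NC(=O)CO[N+](=O)[O-])cc2)cc1` — 33%
Compound 3 `O=C(CO[N+](=O)[O-])Nc1ccc(C(=O)/C=C/c2ccco2)cc1` — 34%

Compound 1 gives the largest of the three numbers, but its gaps to compound 3 and to compound 2 both lie within the usual scatter, so no order among them can be claimed. Compound 4 `CC(Br)C(=O)Nc1ccc(C(=O)/C=C/c2ccc(Cl)cc2)cc1` differs from compound 1 by (1-bromoethyl)carbonyl in place of hydrogen on a nitrogen on an aromatic ring. Among the compounds with values here, the only step measured between two compounds, a number 1 percentage points higher from compound 2 to compound 3 (within the scatter), alters the group on the double-bonded chain carbon, not the nitrogen, and so does not bear on this change. Compounds 2 and 3 do carry an acyl group on that nitrogen and give numbers close to that of compound 1. Compound 4 is therefore expected to show a number 5 percentage points lower from compound 1 to compound 4 (within the scatter), an estimate of 36% with a range of 26% to 46%.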

Compound 4, a percentage reported as inhibition, in the whole organism at one dose (the size of the read-out at that dose, not a potency): 39%
Compound 4: middle estimate off by 3 percentage points, on the low side; low and high end bracket the measured number.
By their numbers in this assay, from the lowest: compounds 2, 3, 4 and 1 (each within the scatter of the next).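

In this assay the change on the nitrogen on an aromatic ring can now be read directly, as a number 2 percentage points lower from compound 1 to compound 4 (within the scatter) with (1-bromoethyl)carbonyl in place of hydrogen. At this one dose, the amino group and the ((1-bromoethyl)carbonyl)amino group therefore cannot be told apart. Nothing at hand explains this result.

The compounds shown leave open whether a plain acetyl group, without the bromine, or a longer chain on the carbonyl would give a number beyond the scatter from compound 1.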